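Lengthening the nitrile chain on a shared core

A few compounds are considered here, and "the series" means these few. Any claim that something is new, unique, unknown or untested is made for them only; others in the source may bear on it.

Compound 1 `C=CCc1cc(C(C)=O)c(O)cc1OCCCCCC#N`, compound 2 `C=CCc1cc(C(C)=O)c(O)cc1OCCCCCCCC#N` and compound 3 `C=CCc1cc(C(C)=O)c(O)cc1OCCCCCCCCC#N` share one core and differ only in how far the chain ending in a nitrile reaches. In an assay on isolated protein for binding affinity to leukotriene B4 receptor 1 (Homo sapiens), tested at 1 uM (a lower number here means less inhibition, a higher number more inhibition at the concentration tested (going by the name of the read-out)), compound 1 gives 41%, compound 2 gives 52%, and compound 3 gives 50%. The change from compound 1 to compound 2 is 2-cyanoethyl in place of cyano on a saturated chain carbon, five bonds along the chain from an oxygen on an aromatic ring, and it made a step of a number 11 percentage points higher from compound 1 to compound 2 (beyond the scatter). Going on from compound 2, the step is a number 2 percentage points lower from compound 2 to compound 3 (within the scatter), so the extra length brought no gain that can be told apart from noise.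

Compound 4 `C=CCc1cc(C(C)=O)c(O)cc1OCCCCCCCCCCC#N` has not yet been measured. It differs from compound 3 by 2-cyanoethyl in place of cyano on a saturated chain carbon, eight bonds along the chain from an oxygen on an aromatic ring. For the measured compounds named here, this is the same kind of change as the one from compound 1 to compound 2, but not the same: in that case the place was on a saturated chain carbon, five bonds along the chain from an oxygen on an aromatic ring, whereas here it is eight bonds along the chain from that oxygen. The two starting points also differ: compound 3 differs from compound 1 by 3-cyanopropyl in place of cyano on a saturated chain carbon, five bonds along the chain from an oxygen on an aromatic ring, which gave a number 9 percentage points higher from compound 1 to compound 3 (within the scatter).

Because a number 2 percentage points lower from compound 2 to compound 3 (within the scatter), further lengthening is expected to change little, so a step of a number 1 percentage points higher from compound 3 to compound 4 (within the scatter) is expected. Compound 4 is estimated to give 51%, likely between 38% and 64%.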

Compound 4, a percentage reported as inhibition, at one concentration (the size of the read-out at that concentration, not a potency): 14%
Compound 4: middle estimate off by 37 percentage points, on the high side; the measured number lies below the stated range.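

In this assay, extending the chain further gave a number 36 percentage points lower from compound 3 to compound 4 (beyond the scatter), so a change that raised the number on the shortest chain does not carry over to the longest chains: the same change on two cores in this assay, a number 11 percentage points higher (beyond the scatter) from compound 1 to compound 2 and a number 36 percentage points lower (beyond the scatter) from compound 3 to compound 4, 47 percentage points apart, beyond the scatter of two such steps Compound 4 also stands apart from the other two compounds, with a number 38 percentage points lower from compound 2 to compound 4 (beyond the scatter) and a number 27 percentage points lower from compound 1 to compound 4 (beyond the scatter), and a second pairing of steps points the same way: the same change on two cores in this assay, a number 9 percentage points higher (within the scatter) from compound 1 to compound 3 and a number 38 percentage points lower (beyond the scatter) from compound 2 to compound 4, 47 percentage points apart, beyond the scatter of two such steps In these four compounds, then, the result of adding to the chain depends on where along the chain the addition is made, but the data do not show why this happens, whether the fall is sudden or gradual, or whether it would recur with other groups on the shared core.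

Still open, on these data alone, is what a longer chain than that of compound 4 would give, and whether a carboxylic acid or an amine at the chain end, in place of the nitrile, would behave as the nitrile compounds do at these chain lengths. Also open, as far as these compounds go, is whether the stronger and weaker effects seen here, each read at a single concentration, would hold at other concentrations.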